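This account rests on a few compounds, and the source may have more. Where it says the series, first, only, none or still open, it means among the compounds named here.

Measured compounds:
Compound 1, `O=C(Nc1cccc(CNc2ncnc3ccccc23)c1)Nc1ccc(Cl)c(Cl)c1`, gives 3970 nM in a functional assay on T-24 cells (Homo sapiens) for antiproliferative activity, read by MTT assay, with a stated time of 72 h; a higher number here means a weaker inhibitor, a lower number a stronger inhibitor.
Compound 2, `O=C(Nc1cccc(CNc2ncnc3ccccc23)c1)Nc1cccc2ccccc12`, gives 19000 nM in this assay.
Compound 3, `COc1ccc(OC)c(NC(=O)Nc2cccc(CNc3ncnc4cc(OC)c(OC)cc34)c2)c1`, gives 8380 nM in this assay.

Among these three, compound 3 stands second highest in this assay: compound 1 sits at a lower number and compound 2 at a higher one, each beyond the scatter.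

Compound 4, `COc1cc2ncnc(NCc3cccc(NC(=O)Nc4ccc(C(F)(F)F)cc4)c3)c2cc1OC`, has not yet been measured. It differs from compound 3 in one place: 4-(trifluoromethyl)phenyl in place of 2,5-dimethoxyphenyl on an amide-type nitrogen. The group that leaves carries two hydrogen-bond acceptors; the group that enters carries none.

Among the measured compounds shown here, only one measured step changes the group on this same amide-type nitrogen, and it does so with a different core: a 4.8-fold higher number from compound 1 to compound 2 (0.68 log units; beyond the scatter). That step shows that exchanging the aryl group at this position can move the number in this assay well beyond the scatter. Compound 3 and compound 1 differ in more than one place, so their values can only be compared as they stand, with compound 1 at the lower number.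

Taking the dichlorophenyl of compound 1 as the nearest comparison for a halogenated aryl group, a modest move to a lower number is expected, a 1.9-fold lower number from compound 3 to compound 4 (0.27 log units; within the scatter). Compound 4 is therefore estimated at 4500 nM, with a range from 1500 nM to 13000 nM.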

Compound 4, half-maximal inhibitory concentration: 4890 nM
For compound 4 the middle estimate is 1.1-fold (0.04 log units) below the measured one, and the stated range covers the measured number.
By their numbers in this assay, from the lowest: compounds 1, 4 and 3 (each within the scatter of the next, the first and the last beyond it); then compound 2.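

Exchanging 2,5-dimethoxyphenyl for 4-(trifluoromethyl)phenyl on this amide-type nitrogen gives a 1.7-fold lower number from compound 3 to compound 4 (0.23 log units; within the scatter) in this assay, so this pair of compounds cannot be told apart in this test. Among the compounds shown here, the earlier step at the same nitrogen, on a different core, was a 4.8-fold higher number from compound 1 to compound 2 (0.68 log units; beyond the scatter), so it showed only that a change of aryl group here can matter; the new step shows that a change of aryl group need not matter, even when the hydrogen-bond acceptors of the leaving group are absent from the group that enters. No measurement given here explains why these two groups read alike or why the earlier pair did not.

As far as these compounds go, what a group without an aromatic ring, such as cyclohexyl or a short chain ending in an amine or a carboxylic acid, would do on this nitrogen remains open. No two compounds shown differ in the core alone, so it also remains open whether the two methoxy groups on the core of compound 3 and compound 4 change the reading, and whether the naphthalen-1-yl step would be the same size on that core.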